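This account rests on a few compounds, and the source may have more. Where it says the series, first, only, none or still open, it means among the compounds named here.

Of the compounds shown here, three that share one core have so far been tested in a functional assay on the whole organism (strain CD-1) with Mus musculus as the target, with a stated time of 0.5 h; on this read-out higher numbers stand for an effect only at larger amounts of compound and lower numbers for an effect already at smaller amounts. Compound 1 `CC1(c2ccccc2)CC(=O)N(CC(=O)N2CCOCC2)C1=O` gives 300 mg/kg. Compound 2 `CC1(c2ccccc2)CC(=O)N(CC(=O)N2CCN(c3ccccc3Cl)CC2)C1=O` is reported as "not active" (no number reported), so it contributes no number. For the measured compounds named here, compound 3 `CC1(c2ccccc2)CC(=O)N(CC(=O)N2CCN(c3ccccc3)CC2)C1=O` gives 100 mg/kg, which is the lowest of the two numbers known; compound 1 stands at a higher number, a gap that lies beyond the usual scatter of this kind of measurement, and compound 2 cannot be placed against it. The next compound, compound 4 `Cc1cccc(N2CCN(C(=O)CN3C(=O)CC(C)(c4ccccc4)C3=O)CC2)c1`, has not yet been measured in this assay. It is built from compound 3 by a single change: methyl in place of hydrogen on an aromatic carbon. Going by the values given here, no pair of already measured compounds differs in just this way, so there is no direct guide to what the change does here. The expected step is modest, a 1.5-fold higher number from compound 3 to compound 4 (0.18 log units; within the scatter), and may not reach beyond the scatter in either direction. On this basis compound 4 is expected to give about 150 mg/kg, within a range from 75 mg/kg to 300 mg/kg.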

Compound 4, minimum effective dose: "not active" (no number reported)
The entry for compound 4 holds no number, so the estimate cannot be set against anything.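

For the compounds shown here, compound 4 is reported in this assay without a number, so no step from compound 3 to compound 4 can be read. No available evidence bears on this result. The compounds shown leave open how far phenyl to 3-methylphenyl shifts the effective dose.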